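The source may report more compounds than this note shows. Statements on the series, on what has been measured and on what is new or still open speak of the compounds shown alone.

Measured in a functional assay on KB cells (Homo sapiens) for cytotoxicity, read by MTT assay, with a stated time of 3 days; a lower number here means a stronger inhibitor, a higher number a weaker inhibitor:

- compound 1 `C=C1c2c(C)nc(OC)c(C#N)c2N=CN1CCC` gives > 50000 nM; this is a limit of the assay, not a number.
- compound 2 `C=C1c2c(C)nc(OC)c(C#N)c2N=CN1CCCCCC` gives > 50000 nM; this too is a limit of the assay, not a number.
- compound 3 `C=C1c2c(C)nc(OC)c(C#N)c2N=CN1Cc1ccc(Cl)cc1` gives 20000 nM.

Going by the values given here, compound 3 thus holds the only numerical value in this assay; the other two entries are limits, which is what the limit of > 50000 nM in this assay, at which 2 of the 3 values shown sit, records. The steps into compound 3 are an at least 2.5-fold lower number from compound 1 to compound 3 (0.39 log units; beyond the scatter) and an at least 2.5-fold lower number from compound 2 to compound 3 (0.39 log units; beyond the scatter), both readable only as lower bounds. The step that the two limits leave unreadable from compound 1 to compound 2 gives no size.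

Compound 4 `C=C1c2c(C)nc(OC)c(C#N)c2N=CN1Cc1cccc(C)c1` differs from compound 3 by 3-methylphenyl in place of 4-chlorophenyl on a saturated chain carbon bound to an amine nitrogen in a ring. The measured steps concern an exchange of a short or medium chain for an aryl group on the same carbon; none compares one aryl group with another, so they do not fix the size of this step. They do show that an aryl group at this position is the one case with a readable number. The step from compound 3 to compound 4 is therefore expected to lie within the scatter, with no direction claimed: a 1.3-fold higher number from compound 3 to compound 4 (0.10 log units; within the scatter). For compound 4 the expected value in this assay is 25000 nM, in the range 10000 nM to 60000 nM.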

Compound 4, half-maximal inhibitory concentration: 37000 nM
For compound 4 the middle estimate is 1.5-fold (0.17 log units) below the measured one; the measured number falls inside the stated range.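

In this assay, going by these compounds alone, this is the first comparison of one aryl group with another on this saturated chain carbon: a 1.9-fold higher number from compound 3 to compound 4 (0.27 log units; within the scatter), so 3-methylphenyl and 4-chlorophenyl are not told apart here. Compounds 3 and 4 both carry an aryl group and both give a number, so the readable result is no longer confined to the 4-chlorophenyl group. Against the chains, only floors can be read, an at least 1.3-fold lower number from compound 2 to compound 4 (0.13 log units; that floor lies within the scatter) and an at least 1.3-fold lower number from compound 1 to compound 4 (0.13 log units; that floor lies within the scatter), and these do not separate compound 4 from the chain compounds, because those compounds sit at a limit and not at a number: the limit of > 50000 nM in this assay, at which 2 of the 4 values shown sit.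

The swap changes the group's substituent and its place on the ring together, so 3-chlorophenyl and 4-methylphenyl would be needed to part the two. Also open, on these data alone, is whether an aryl group bearing an amine or a carboxylic acid gives a number in the same range.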